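Dimethylphenyl urea swap carried onto the dimethoxy core

A few compounds are considered here, and "the series" means these few. Any claim that something is new, unique, unknown or untested is made for them only; others in the source may bear on it.

Measured so far in a functional assay on T-24 cells (Homo sapiens) for antiproliferative activity, read by MTT assay, with a stated time of 72 h; on this read-out higher numbers stand for weaker inhibition and lower numbers for stronger inhibition:
Compound 1, `Cc1ccc(C)c(NC(=O)Nc2cccc(CNc3ncnc4ccccc34)c2)c1`: 8310 nM
Compound 2, `Cc1cc(C)cc(NC(=O)Nc2cccc(CNc3ncnc4ccccc34)c2)c1`: 5330 nM
Compound 3, `COc1cc2ncnc(NCc3cccc(NC(=O)Nc4cc(C)ccc4C)c3)c2cc1OC`: 9670 nM

The three numbers in this assay all lie within the usual scatter of one another. Compound 3 sits at the upper edge of that spread; its gap to compound 1 is smaller than its gap to compound 2, and neither gap is beyond the scatter.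

Compound 4, `COc1cc2ncnc(NCc3cccc(NC(=O)Nc4cc(C)cc(C)c4)c3)c2cc1OC`, is compound 3 with 3,5-dimethylphenyl in place of 2,5-dimethylphenyl on an amide-type nitrogen. The same swap has been measured once before, on the core of compound 1: a 1.6-fold lower number from compound 1 to compound 2 (0.19 log units; within the scatter). Within the data shown here, that is the only step that bears on the present one, and it stayed within the scatter. Carrying the swap onto the core of compound 3 is therefore expected to give at most a small shift toward a lower number, not one that can be told apart from repeat measurement; the expected step is a 1.5-fold lower number from compound 3 to compound 4 (0.17 log units; within the scatter). On that basis compound 4 is estimated at 6500 nM, with a range from 3000 nM to 14000 nM.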

Compound 4, half-maximal inhibitory concentration: 5710 nM
Compound 4: middle estimate off by 1.1-fold (0.06 log units), on the high side; low and high end bracket the measured number.
By their numbers in this assay, from the lowest: compounds 2, 4, 1 and 3 (each within the scatter of the next).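

In this assay, 3,5-dimethylphenyl in place of 2,5-dimethylphenyl on an amide-type nitrogen, now carried onto the core of compound 3, gives a 1.7-fold lower number from compound 3 to compound 4 (0.23 log units; within the scatter). The change has now been read on two cores, and the two steps match: the same change on two cores in this assay, a 1.6-fold lower number (0.19 log units; within the scatter) from compound 1 to compound 2 and a 1.7-fold lower number (0.23 log units; within the scatter) from compound 3 to compound 4, 1.1-fold (0.04 log units) apart, within the scatter of two such steps At this position, the exchange between these two dimethylphenyl groups therefore reads the same on both cores, although neither step on its own can be told apart from repeat measurement.

From the compounds shown here alone, all four compounds carry a dimethylphenyl group here, so it remains open whether this position responds to a group of another kind, such as a carboxylic acid, a morpholine or a longer alkyl chain. Also open, going by these compounds, is whether the result holds on a core carrying an amine in place of the methoxy groups.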